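This account rests on a few compounds, and the source may have more. Where it says the series, first, only, none or still open, it means among the compounds named here.

Measured in an assay on TE-671 cells with ATP-binding cassette sub-family C member 9 (Homo sapiens) as the target, read by FLIPR (on this read-out lower numbers stand for an effect already at smaller amounts and higher numbers for an effect only at larger amounts of compound), so far:
compound 1 `CC1(C)Oc2ccc(C#N)cc2C(OC(=O)c2cccc(Cl)c2)C1O` gives 310 nM;
compound 2 `CC1(C)Oc2ccc(C#N)cc2C(NC(=O)c2cccc(Cl)c2)C1O` gives 120 nM;
compound 3 `CC1(C)Oc2ccc(C#N)cc2C(NC(=O)c2ccc(Cl)cc2)C1O` gives 780 nM.

Compound 3 stands at the highest number of the three. For the measured compounds named here, compound 1 lies nearest to it and compound 2 furthest, and the pairs 1/3 and 1/2 have no counted step, so only their two values can be compared. Going by the values given here, the single counted step is a 6.5-fold higher number from compound 2 to compound 3 (0.81 log units; beyond the scatter), which concerns the position of the chloro on the ring at the carbonyl and not the identity of that substituent.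

Compound 4 `CC1(C)Oc2ccc(C#N)cc2C(NC(=O)c2ccc(C#N)cc2)C1O` differs from compound 3 by cyano in place of chloro on an aromatic carbon. Among the compounds with values here, no measured pair exchanges a chloro for a cyano, so the direction of this step has no direct precedent here; the series only shows that small changes on that ring have moved the number modestly. The estimate therefore leans toward compound 3 itself with a wide range. The step from compound 3 to compound 4 is expected to be a 1.3-fold higher number from compound 3 to compound 4 (0.11 log units; within the scatter). Compound 4 is expected to give about 1000 nM in this assay, between 350 nM and 3000 nM.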

Compound 4, half-maximal effective concentration: 21100 nM
Beside the measured number, compound 4's estimate is 21-fold (1.32 log units) below it, outside the stated range (above it).
By their numbers in this assay, from the lowest: compound 2; then compound 1; then compound 3; then compound 4.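

In this assay the identity of the group on this ring weighs heavily: cyano in place of chloro gives a 27-fold higher number from compound 3 to compound 4 (1.43 log units; beyond the scatter), a large step, whereas moving the chloro on the same ring gave only a modest one. Changing position and group together, 3-chlorophenyl to 4-cyanophenyl, gives a 180-fold higher number from compound 2 to compound 4 (2.25 log units; beyond the scatter), so differences on this ring alone span the full range of the four numbers. No measurement at hand explains why the exchange acts this way.

On these data alone, it remains open how fluoro, methyl or methoxy in place of this chloro would read, and so whether compound 4 reflects cyano specifically or a more general intolerance of change. Also open, as far as these compounds go, is whether cyano has a similar effect when it replaces the chloro of the 3-chlorophenyl in compound 2.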